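A few compounds are considered here, and "the series" means these few. Any claim that something is new, unique, unknown or untested is made for them only; others in the source may bear on it.

Compound 1 `O=C(O)CC/C=C\CC1COC(c2ccc([N+](=O)[O-])cc2)OC1c1cccnc1`: 933 nM
Compound 2 `CC(C)(Oc1ccccc1)C1OCC(C/C=C\CCC(=O)O)C(c2cccnc2)O1`: 75.9 nM

In a functional assay for inhibition, with Homo sapiens as the target (a lower number here means tighter binding, a higher number weaker binding), compound 2 has the lower of the two numbers, at 75.9 nM. Compound 3 `CC(C)(C)c1ccc(OC(C)(C)C2OCC(C/C=C\CCC(=O)O)C(c3cccnc3)O2)cc1` differs from compound 2 in one place: tert-butyl in place of hydrogen on an aromatic carbon. With tert-butyl in place of hydrogen on an aromatic carbon, phenoxy becomes 4-(tert-butyl)phenoxy.

Among the measured compounds shown here, only one measured step bears on this change, and only indirectly: a 12-fold lower number from compound 1 to compound 2 (1.09 log units; beyond the scatter). That large step exchanged a whole group, and the group entering compound 2 is the one that now gains the tert-butyl. It shows that this part of the structure can move the number in this assay. For the measured compounds named here, no measured pair tests a substituent on the phenoxy group, so the direction remains uncertain, and the data offer only a weak lean towards a lower number.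

A smaller change than the measured step is expected, an estimated 2.2-fold lower number from compound 2 to compound 3 (0.34 log units; beyond the scatter). For compound 3 the expected value is 35 nM, with an estimated range of 9 nM to 140 nM.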

Compound 3, dissociation constant: 1910 nM
Beside the measured number, compound 3's estimate is 55-fold (1.74 log units) below it, and the stated range ends below it.
By their numbers in this assay, from the lowest: compound 2; then compound 1; then compound 3.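

Going from phenoxy to 4-(tert-butyl)phenoxy gives a 25-fold higher number from compound 2 to compound 3 (1.40 log units; beyond the scatter) in this assay, so this aromatic carbon, para to a large group, is a place where one added tert-butyl has a large effect on the number. The earlier step had shown only that exchanging a whole group on the saturated ring carbon could lower the number; this step, also beyond the scatter, runs the opposite way and shows that enlarging the group that gave the improvement does not carry that gain further. Nothing in the data available here accounts for the rise.

The compounds shown leave open whether this rise belongs to tert-butyl in particular or would follow any substituent on this carbon, which a fluorine atom, a methyl group or a methoxy group in the same place would help to separate. They also leave open whether tert-butyl would have the same effect on another carbon of the aromatic ring, and whether a hydroxyl group or an amine there would push the number in the other direction.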